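Pentyl Replaces Difluorophenyl on a Cytotoxicity Limit

The source may report more compounds than this note shows. Statements on the series, on what has been measured and on what is new or still open speak of the compounds shown alone.

Compound 1, `CCCCOC(=O)Nc1cc2nc(C3CCCCC3)[nH]c2cc1N(C)C`, sits at a limit in an ADME assay on Vero cells (Chlorocebus sabaeus) for cytotoxicity, read by resazurin assay, with a stated time of 3 days; a higher number here means a weaker inhibitor, a lower number a stronger inhibitor: > 100 ug/mL.
Compound 2, `CN(C)c1cc2[nH]c(C3CCCCC3)nc2cc1NC(=O)c1ccc(F)cc1F`, sits at a limit in this assay: > 100 ug/mL.

Compound 2 thus stands not at a number but at a limit of this assay, together with compound 1 at the limit of > 100 ug/mL in this assay, at which 2 of the 2 values shown sit. Compound 3, `CCCCCC(=O)Nc1cc2nc(C3CCCCC3)[nH]c2cc1N(C)C`, differs from compound 2 in one place: pentyl in place of 2,4-difluorophenyl on a carbonyl carbon. Among the compounds with values here, the only measured step touching this position is a step that the two limits leave unreadable from compound 1 to compound 2, which also swapped the group on the same carbonyl carbon and left no readable size. Nothing measured points in either direction, so for this assay the expected step is none beyond the scatter. The step from compound 2 to compound 3 is accordingly estimated as a number no higher from compound 2 to compound 3 (the limit leaves the size open). Compound 3 is expected to give about 100 ug/mL, between 50 ug/mL and 200 ug/mL, and most probably again only as a limit.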

Compound 3, half-maximal inhibitory concentration: > 100 ug/mL
Compound 3: a limit, no number; the forecaster's own chance of this, stated with the estimate: 80%; the middle value sits exactly at the limit.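

Compound 3 gives a limit, not a number, so no step among compound 1, compound 2 and compound 3 can be read: the limit of > 100 ug/mL in this assay, at which 3 of the 3 values shown sit.

The compounds shown leave open whether butoxy, 2,4-difluorophenyl or pentyl on the carbonyl carbon makes any difference in this assay.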